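Changing the Phenyl Group on an Amide Nitrogen

This account rests on a few compounds, and the source may have more. Where it says the series, first, only, none or still open, it means among the compounds named here.

Compound 1 `O=C(CN1CCN(c2nnc(Cc3ccncc3)c3ccccc23)CC1)Nc1cccc(Br)c1` and compound 2 `O=C(CN1CCN(c2nnc(Cc3ccncc3)c3ccccc23)CC1)Nc1ccc(F)c(Cl)c1` share one core and differ only in the phenyl group on an amide-type nitrogen. In a functional assay on HT-29 cells (Homo sapiens) for cytotoxicity, read by MTT assay, with a stated time of 72 h (a lower number here means a stronger inhibitor, a higher number a weaker inhibitor), compound 1 gives 1350 nM and compound 2 gives 880 nM. On these numbers, compound 2 stands level with compound 1 within the scatter.

Compound 3 `O=C(CN1CCN(c2nnc(Cc3ccncc3)c3ccccc23)CC1)Nc1cc(C(F)(F)F)ccc1Cl` keeps the shared core but carries 2-chloro-5-(trifluoromethyl)phenyl in place of 3-chloro-4-fluorophenyl on the same nitrogen: 2-chloro-5-(trifluoromethyl)phenyl in place of 3-chloro-4-fluorophenyl on an amide-type nitrogen. Among the compounds with values here, the only measured guide is the earlier exchange at this place, a 1.5-fold lower number from compound 1 to compound 2 (0.19 log units; within the scatter). That single step was small, and it cannot show a trend. Within the data shown here, no measured compound carries a trifluoromethyl group, so the data leave this part of the change untested. In this assay, no step beyond the scatter is therefore expected, although the uncertainty is wide in either direction. The expected change is a 1.1-fold higher number from compound 2 to compound 3 (0.06 log units; within the scatter). Compound 3 is expected to give about 1000 nM, with an estimated range from 350 nM to 3000 nM.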

Compound 3, half-maximal inhibitory concentration: 4810 nM
Compound 3: the middle estimate sits 4.8-fold (0.68 log units) below what was measured; the whole stated range lies below it.
By their numbers in this assay, from the lowest: compounds 2 and 1 (each within the scatter of the next); then compound 3.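

This position on the amide-type nitrogen is not indifferent to the group it carries: in this assay, 2-chloro-5-(trifluoromethyl)phenyl in place of 3-chloro-4-fluorophenyl gives a 5.5-fold higher number from compound 2 to compound 3 (0.74 log units; beyond the scatter), and in place of 3-bromophenyl it gives a 3.6-fold higher number from compound 1 to compound 3 (0.55 log units; beyond the scatter). Compound 1 and compound 2 stood level within the scatter, so only compound 3 shows that a change at this place can produce a measurable loss, with both steps pointing towards a weaker inhibitor. No evidence here bears on what lies behind this loss.

The exchange alters more than one feature at once, since the chlorine sits at a different ring position, the fluorine goes and a trifluoromethyl group enters, and the three compounds cannot show which of these changes matters. A plain phenyl group, or a phenyl group carrying only a trifluoromethyl group, would help separate these changes, while a phenyl group bearing a methoxy group or a carboxylic acid would test whether this position accepts substituents of a quite different kind.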